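The source may report more compounds than this note shows. Statements on the series, on what has been measured and on what is new or still open speak of the compounds shown alone.

Measured compounds:
Compound 1, `CCCc1cc(N2CCCC2)c2cc(NC(=O)/C=C/c3ccc(C(F)(F)F)cc3)ccc2n1`: 2800 nM
Compound 2, `CC(C)(C)c1cc(N)c2cc(NC(=O)/C=C/c3ccc(C(F)(F)F)cc3)ccc2n1`: 29 nM

Both compounds were tested in a functional assay on HEK293 cells for activation of melanin-concentrating hormone receptor 1 (Homo sapiens), read by inositol phosphate accumulation; a lower number here means that less compound is needed, a higher number that more compound is needed for the effect. Compound 2 stands at the lower of the two numbers, and the gap to compound 1 is well beyond the usual scatter. Going by the values given here, compound 1 differs from compound 2 in two places at once, so the pair shows only that much less of compound 2 is needed, without telling which of the two changes matters.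

Compound 3, `Nc1cc(C2CCCC2)nc2ccc(NC(=O)/C=C/c3ccc(C(F)(F)F)cc3)cc12`, has not been measured yet. It differs from compound 2 in a single place: cyclopentyl in place of tert-butyl on an aromatic carbon. Both groups are made of carbon only, carry no hydrogen-bond donors or acceptors and are close in size, the one that enters being larger by one heavy atom and closed into a ring.

Among the compounds with values here, no single-change step between measured compounds is available, so there is no measured yardstick for such a swap. The expectation is a step of a 1.2-fold higher number from compound 2 to compound 3 (0.08 log units; within the scatter), that is, none beyond the scatter in this assay. For compound 3 the estimated value is 35 nM, with a range from 12 nM to 100 nM.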

Compound 3, half-maximal effective concentration: 68 nM
Compound 3: middle estimate off by 1.9-fold (0.29 log units), on the low side; the measured number falls inside the stated range.
By their numbers in this assay, from the lowest: compound 2; then compound 3; then compound 1.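

In this assay, going by these compounds alone, the step to cyclopentyl is the first single-place change in this set: a 2.3-fold higher number from compound 2 to compound 3 (0.37 log units; beyond the scatter). It shows that this aromatic carbon, next to the ring nitrogen, does distinguish between two groups made of carbon only, even though neither carries a hydrogen-bond donor or acceptor. The difference is modest, so a five-membered non-aromatic ring of carbon only can take the place of tert-butyl with a small but real rise in the amount of compound needed, and nothing available here explains that rise.

This single step changes two things together, the heavy-atom count and the closing of a ring, so it cannot say which of them matters. It also gives only a narrow view of this position: a cyclobutyl or cyclohexyl ring, an open chain such as isopropyl or n-butyl, or an aromatic phenyl ring on the same carbon would show how far the trend holds and whether the position accepts anything beyond these two groups.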